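The compounds below may be only part of what the source reports. "The series", "measured", "known", "first", "only" and "open" are said of these compounds alone.

Compound 3 `COc1cc(/C=C/C(=O)C2=C(/C=C/c3ccc(O)c(OC)c3)NC(=S)NC2c2ccccc2)ccc1O` gives 22% in a functional assay, with a stated time of 20 min, tested at 10 uM; on this read-out higher numbers stand for a stronger effect at the one concentration tested and lower numbers for a weaker effect; this is the highest of the three numbers shown, but compound 1 `COc1cc(/C=C/C(=O)C2=C(/C=C/c3ccc(O)c(OC)c3)NC(=O)NC2c2c(Cl)cccc2Cl)ccc1O` with 20% and compound 2 `COc1cc(/C=C/C(=O)C2=C(/C=C/c3ccc(O)c(OC)c3)NC(=O)NC2c2cccc([N+](=O)[O-])c2)ccc1O` with 19.9% both lie within the usual scatter of it, so no order among them can be claimed. Compound 4 `COc1cc(/C=C/C(=O)C2=C(/C=C/c3ccc(O)c(OC)c3)NC(=S)NC2c2ccccc2O)ccc1O` differs from compound 3 in one place: hydroxy in place of hydrogen on an aromatic carbon. Within the data shown here, the only measured step that concerns the same six-membered aromatic ring of carbon only on a saturated ring carbon is a number 0.1 percentage points lower from compound 1 to compound 2 (within the scatter), a swap of the whole ring that left the read-out essentially unchanged. Among the measured compounds shown here, no measured step shows a hydroxy group itself, so only a change within the scatter is expected, and for compound 4 the estimated step is no change at the digits printed from compound 3 to compound 4 (within the scatter). Compound 4 is therefore expected to give 22%, with a range from 10% to 34%.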

Compound 4, a percentage reported as activity, at one concentration (the size of the read-out at that concentration, not a potency): 70.8%
Compound 4: middle estimate off by 48.8 percentage points, on the low side, and the stated range ends below it.
By their numbers in this assay, from the lowest: compounds 2, 1 and 3 (each within the scatter of the next); then compound 4.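

In this assay the change from phenyl to 2-hydroxyphenyl gives a number 48.8 percentage points higher from compound 3 to compound 4 (beyond the scatter), so this ring is sensitive to substitution at this place. A single added hydroxy, ortho to a large group, is enough, whereas the ring swap in the earlier step gave only a number 0.1 percentage points lower from compound 1 to compound 2 (within the scatter). No measurement here explains why this hydroxy matters so much. On these data alone, whether a methoxy group or an amine on the same carbon would give a similar read-out stays open. So does whether a hydroxy on another carbon of this ring would do the same.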